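The source may hold more compounds than are shown below. What is called first, only, known or untested is meant among the compounds shown, and "the series" means these compounds.

Measured compounds:
compound 1, `CCCCCCOc1ccc(-n2cnnc2CCCC)cc1`, 13.6 mg/kg in a functional assay on the whole organism (strain C57B/6) with Mus musculus as the target, in the maximal electroshock model; on this read-out higher numbers stand for an effect only at larger amounts of compound and lower numbers for an effect already at smaller amounts
compound 2, `CCCCCCOc1ccc(-n2cnnc2CCCCC)cc1`, 32.8 mg/kg in this assay

Compound 2 stands at the higher of the two numbers in this assay; the nearest is compound 1, and the step of a 2.4-fold higher number from compound 1 to compound 2 (0.38 log units; beyond the scatter) places compound 2 beyond the scatter of compound 1. The candidate compound 3, `CCCCCCOc1ccc(-n2cnnc2-c2ccccc2)cc1`, has not yet been tested. Its change from compound 2 is phenyl in place of pentyl on an aromatic carbon. Going by the values given here, the only measured step, a 2.4-fold higher number from compound 1 to compound 2 (0.38 log units; beyond the scatter), concerns a methyl added to a saturated chain and does not involve a ring entering in place of a chain, so it bears on the new step only loosely: it shows that a change at this position of the shared core can move the number by a modest amount in either direction, but it does not indicate which way a phenyl in place of pentyl would go. Among the compounds with values here, with no closer precedent, the expectation for compound 3 in this assay is a step of a 1.3-fold lower number from compound 2 to compound 3 (0.12 log units; within the scatter), that is no change clearly beyond the scatter, with wide uncertainty. Compound 3 is therefore estimated at 25 mg/kg, within a range of 8 mg/kg to 80 mg/kg.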

Compound 3, dose for half-maximal effect: 19 mg/kg
Estimate against measurement, compound 3: 1.3-fold (0.12 log units) above; the range from low to high includes it.
By their numbers in this assay, from the lowest: compounds 1, 3 and 2 (each within the scatter of the next, the first and the last beyond it).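

In this assay, going by these compounds alone, the earlier pair showed this aromatic carbon carrying saturated chains only, with a 2.4-fold higher number from compound 1 to compound 2 (0.38 log units; beyond the scatter) as the one step between them. Phenyl now brings a six-membered aromatic ring of carbon only to the same place, with a 1.7-fold lower number from compound 2 to compound 3 (0.24 log units; within the scatter) and a 1.4-fold higher number from compound 1 to compound 3 (0.15 log units; within the scatter) as its steps, so compound 3 lies within the scatter of both chain compounds, even though those two lie beyond the scatter of each other. A saturated chain is thus not needed on this carbon for a number in the range of compound 1 and compound 2, although nothing available explains why the ring fits this range.

On these data alone, the three compounds carry only butyl, pentyl and phenyl here, all of carbon alone, so what a ring or chain holding nitrogen or oxygen would do remains open, for example an amine, a carboxylic acid or a pyridine ring in place of phenyl. Also open, as far as these compounds go, is whether a chain shorter than butyl, such as methyl, or a phenyl bearing chlorine would stay within the same range.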